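The compounds below may be only part of what the source reports. "The series", "measured", "known", "first", "only" and "open" are said of these compounds alone.

Of the compounds shown here, two from this study have been measured so far. The first, compound 1 `CC(=O)Nc1cc(OCc2ccccc2)nc(SCc2ccccc2)n1`, gives 42900 nM in a functional assay on HepG2 cells (Homo sapiens) for antiproliferative activity, read by MTT assay, with a stated time of 72 h; on this read-out lower numbers stand for stronger inhibition of growth and higher numbers for weaker inhibition of growth. The second, compound 2 `COc1cc(OC)n2cc(-c3ccc(N)cc3)nc2n1`, reaches only the limit of this assay, reported as > 100000 nM, so for compound 2 a limit rather than a number is known. This limit is the one described as the limit of > 100000 nM in this assay, at which 1 of the 2 values shown sits, and it marks the edge of what the assay can report. Among the compounds with values here, no single-point step between compound 1 and compound 2 is defined, since they differ in more than one place, so their two values are simply set side by side: one a number, the other a limit.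

The next compound, compound 3 `COc1cc(OC)n2cc(-c3ccc(NCc4ccccc4)cc3)nc2n1`, is compound 2 with one change: benzyl in place of hydrogen on a nitrogen on an aromatic ring. Starting from a limit, no measured step guides the expectation for this change. Compound 3 is therefore estimated at 60000 nM, with a range from 15000 nM to 200000 nM, and the expected step of an at least 1.6-fold lower number from compound 2 to compound 3 (0.22 log units; that floor lies within the scatter) is taken as a modest move toward stronger growth inhibition, with a fair chance that this assay again reports only a limit.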

Compound 3, concentration for 50% growth inhibition: > 100000 nM
Compound 3: only a limit was reported (the forecaster's own chance of this, stated with the estimate: 45%); middle value at least 1.6-fold (0.22 log units) away from the limit.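

Compound 2 and compound 3 both stand at a limit rather than a number in this assay, so no step can be read from the change between them: the limit of > 100000 nM in this assay, at which 2 of the 3 values shown sit.

The compounds shown leave open whether benzyl in place of hydrogen on a nitrogen on an aromatic ring changes growth inhibition at all, and in which direction.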